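A few compounds are considered here, and "the series" means these few. Any claim that something is new, unique, unknown or untested is made for them only; others in the source may bear on it.

Compound 1, `CCn1cc(NC(=O)C(=O)Nc2ccc(Cl)cc2)cn1`: 8000 nM
Compound 2, `Cc1nc(C(NC(=O)C(=O)Nc2ccc(F)c(Cl)c2)C2CCCCN2)sc1CO`: > 77800 nM
Compound 3, `Cc1nc(C(NC(=O)C(=O)Nc2ccc(F)c(Cl)c2)C2CCCCN2)sc1CCO`: > 75800 nM

Three compounds have been run in an ADME assay on TZM-b1 cells (Homo sapiens) for cytotoxicity, read by XTT assay, with a stated time of 3 days; on this read-out higher numbers stand for lower toxicity in this test and lower numbers for higher toxicity in this test. Compound 1 gives 8000 nM, a measured number. Compound 2 gives only a limit, > 77800 nM, so its true value is not known beyond (the limit of > 77800 nM in this assay, at which 1 of the 3 values shown sits). Compound 3 likewise gives only a limit, > 75800 nM, standing at the limit of > 75800 nM in this assay, at which 1 of the 3 values shown sits. Among the compounds with values here, the one change within this set that alters a single place, a step that the two limits leave unreadable from compound 2 to compound 3, has both ends at a limit and its size cannot be read. Where compound 2 stands on the numbers shown is therefore only this: at a limit, with one further value of the set also sitting at a limit, and with compound 1 as the only measured number.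

Compound 4, `Cc1nc(C(NC(=O)C(=O)NC2CCCCCC2)C2CCCCN2)sc1CO`, differs from compound 2 by cycloheptyl in place of 3-chloro-4-fluorophenyl on an amide-type nitrogen. Within the data shown here, none of the measured compounds carries cycloheptyl on this amide-type nitrogen, so no measured step speaks to the change, and the one step that exists cannot be sized. What can be said is that compound 2 sits at a limit, and the expectation for compound 4 is built from that alone: the step of an at least 1.2-fold lower number from compound 2 to compound 4 (0.11 log units; that floor lies within the scatter) is expected to lie within the scatter. Compound 4 is thus estimated at 60000 nM, with a range from 20000 nM to 100000 nM, and a fair chance that the assay again reports only a limit.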

Compound 4, half-maximal cytotoxic concentration: > 90000 nM
Compound 4: a limit, no number; the forecaster's own chance of this, stated with the estimate: 55%; at least 1.5-fold (0.17 log units) between middle value and limit.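

In this assay, compound 2 and compound 4 both stand at a limit, so no step can be read from compound 2 to compound 4. The compounds shown leave open whether cycloheptyl or 3-chloro-4-fluorophenyl on the amide-type nitrogen gives the higher number, as the true values of compound 2, compound 3 and compound 4 remain unknown.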